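A few compounds are considered here, and "the series" means these few. Any claim that something is new, unique, unknown or untested is made for them only; others in the source may bear on it.

Of the compounds shown here, three built on one shared core have been measured in a functional assay on NCI-H460 cells (Homo sapiens) for positive allosteric modulation, read by MTT assay, with stated times of 2 h and 72 h, tested at 10 uM; on this read-out lower numbers stand for stronger inhibition and higher numbers for weaker inhibition. Compound 1 `COc1ccc(C(=O)Nc2ccccc2-c2nnn(-c3ccc(OC)cc3)n2)cc1` gives 149 nM. Among the compounds with values here, compound 2 `COc1cccc(-n2nnc(-c3ccccc3NC(=O)c3ccc(N)cc3)n2)c1` gives 211 nM, and compound 3 `COc1cccc(-n2nnc(-c3ccccc3NC(=O)c3ccc(N=[N+]=[N-])cc3)n2)c1` gives 415 nM, the highest of the three numbers; its gap to compound 1 lies beyond the scatter, while the only single-point step, a 2.0-fold higher number from compound 2 to compound 3 (0.29 log units; within the scatter), stays within it. Compound 4 `COc1cccc(-n2nnc(-c3ccccc3NC(=O)Nc3ccc(N)cc3)n2)c1` has not yet been measured. It differs from compound 3 in one place: (4-aminophenyl)amino in place of 4-azidophenyl on a carbonyl carbon. Within the data shown here, the measured step bears on this change only in part, since the amino group that enters also appears in compound 2, and no step shows what the (4-aminophenyl)amino linkage itself does. A step of a 1.5-fold lower number from compound 3 to compound 4 (0.17 log units; within the scatter) is therefore expected. Compound 4 is estimated at 280 nM, within a range from 90 nM to 900 nM.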

Compound 4, half-maximal inhibitory concentration: 176 nM
The estimate for compound 4 lay 1.6-fold (0.20 log units) above the measured number; the measured number falls inside the stated range.
By their numbers in this assay, from the lowest: compounds 1, 4, 2 and 3 (each within the scatter of the next, the first and the last beyond it).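

On the carbonyl carbon, (4-aminophenyl)amino in place of 4-azidophenyl gives a real gain in inhibition (a 2.4-fold lower number from compound 3 to compound 4 (0.37 log units; beyond the scatter)). Against 4-aminophenyl at the same place, (4-aminophenyl)amino gives a step too small to separate the two groups (a 1.2-fold lower number from compound 2 to compound 4 (0.08 log units; within the scatter)), so this carbonyl carbon accepts either group without a clear difference. No measurement shown here explains these numbers.

Going by these compounds, it remains open whether a carboxylic acid in place of the amino group of compound 4 would hold this level of inhibition. A methylene link in place of the amino linkage is equally untested by these compounds.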